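The source may hold more compounds than are shown below. What is called first, only, known or untested is meant among the compounds shown, and "the series" means these compounds.

Working notes on the series. Two compounds have numbers in an assay on isolated protein for inhibition of Rho-associated protein kinase 2 (Homo sapiens), read by scintillation counting, radiometric assay and 33P incorporation, with a stated time of 40 min, in the presence of a further agent that is not named here; a lower number here means a stronger inhibitor, a higher number a weaker inhibitor. Compound 1 `CC(C)(C)c1ccc(C(=O)Nc2cccc(NC(=O)COc3ccc4c(=O)ccoc4c3)c2)cc1` gives 34 nM in this assay. Compound 2 `O=C(COc1ccc2c(=O)ccoc2c1)Nc1cccc(NC(=O)c2ccc(Br)cc2)c1` gives 49 nM in this assay. Among the measured compounds shown here, compound 2 carries the highest of the two numbers; its only neighbour is compound 1, and the step of a 1.4-fold higher number from compound 1 to compound 2 (0.16 log units; within the scatter) is within the scatter, so on these data the two compounds stand as equals. Compound 3 `COc1ccc(C(=O)Nc2cccc(NC(=O)COc3ccc4c(=O)ccoc4c3)c2)cc1` is not yet measured in this assay. It differs from compound 2 in one place: methoxy in place of bromo on an aromatic carbon. For the measured compounds named here, the single measured step that bears on this position is the exchange from compound 1 to compound 2, where another group sat on the same aromatic carbon and the number hardly moved: a 1.4-fold higher number from compound 1 to compound 2 (0.16 log units; within the scatter). Nothing measured here separates the groups tried at this carbon, and no step beyond the scatter is expected from this change. The expected step in this assay is a 1.0-fold higher number from compound 2 to compound 3 (0.01 log units; within the scatter). Compound 3 is estimated at 50 nM in this assay, within a range from 20 nM to 130 nM.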

Compound 3, half-maximal inhibitory concentration: 7 nM
Beside the measured number, compound 3's estimate is 7.1-fold (0.85 log units) above it, outside the stated range (below it).
By their numbers in this assay, from the lowest: compound 3; then compounds 1 and 2 (each within the scatter of the next).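

In this assay the step of a 7.0-fold lower number from compound 2 to compound 3 (0.85 log units; beyond the scatter) and the step of a 4.9-fold lower number from compound 1 to compound 3 (0.69 log units; beyond the scatter) show that this aromatic carbon, para to a large group, does respond to the group it carries. Bromo and tert-butyl had left the number within the scatter, so that pair gave no sign of this sensitivity, and compound 3 now stands as the strongest inhibitor of the three, with both of its steps beyond the scatter. Against bromo, methoxy adds one heavy atom and one hydrogen-bond acceptor, but no measurement ties the step to either difference, and no evidence on the origin of the gain is available.

The compounds shown leave open whether the gain is particular to methoxy or extends to other groups at this carbon, such as hydroxy, ethoxy or an amine. They also leave open whether a methoxy elsewhere on this six-membered aromatic ring would give a step of similar size, or whether the gain depends on this one position.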